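Trimming a Hydroxyethyl Arm Back to a Hydroxy

This account rests on a few compounds, and the source may have more. Where it says the series, first, only, none or still open, it means among the compounds named here.

Of the compounds shown here, three sharing one core have been measured in a functional assay on DLD-1 cells (Homo sapiens) for antiproliferative activity, read by CellTiter-Glo, with a stated time of 72 h; on this read-out higher numbers stand for weaker inhibition and lower numbers for stronger inhibition. Compound 1 `Cc1cc(Cl)cc(Cl)c1S(=O)(=O)N1CCC(N2CCC(C)CC2)CC1` gives 0.6 nM. Compound 2 `Cc1cc(C)c(S(=O)(=O)N2CCC(N3CCC(CCO)CC3)CC2)c(C)c1` gives 19 nM, and compound 3 `Cc1cccc(S(=O)(=O)N2CCC(N3CCC(C)CC3)CC2)c1` gives 25 nM. Among these three, compound 2 stands second highest; its number sits close to that of compound 3, a gap that falls within the usual scatter of repeated measurements, so no real difference between the two can be claimed, whereas compound 1 lies far beyond that scatter, with a number much lower than either.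

Compound 4 `Cc1cc(C)c(S(=O)(=O)N2CCC(N3CCC(O)CC3)CC2)c(C)c1` has not yet been measured. It differs from compound 2 in one place: hydroxy in place of 2-hydroxyethyl on a saturated ring carbon The side arm on the saturated ring carbon is thus cut back to a hydroxy.

Going by the values given here, no pair of measured compounds differs by this kind of change, so there is no directly comparable step to lean on. Without such a guide, a modest shift in this assay is expected, more likely toward a somewhat higher number than toward a lower one, though not with confidence beyond the scatter. The estimated step is a 2.1-fold higher number from compound 2 to compound 4 (0.32 log units; beyond the scatter). Compound 4 is therefore expected to give about 40 nM in this assay, with a plausible range from 10 nM to 160 nM.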

Compound 4, half-maximal inhibitory concentration: 106 nM
For compound 4 the middle estimate is 2.7-fold (0.42 log units) below the measured one; low and high end bracket the measured number.
By their numbers in this assay, from the lowest: compound 1; then compounds 2 and 3 (each within the scatter of the next); then compound 4.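

In this assay, putting hydroxy in place of 2-hydroxyethyl on the saturated ring carbon gives a 5.6-fold higher number from compound 2 to compound 4 (0.75 log units; beyond the scatter) and this step lies beyond the usual scatter, so this position is not indifferent to the length of the arm that carries the hydroxy. The two groups match in their counts of hydrogen-bond donors and acceptors and neither has a net charge, so what leaves in this change is the carbon part of the chain, while the hydroxy itself stays. Nothing measured here explains why the shorter arm goes with the weaker inhibition.

The compounds shown leave open how a longer chain such as 3-hydroxypropyl, an amine or a carboxylic acid would read on the same ring carbon, so it cannot yet be said whether the trend with arm length continues. Compound 1 and compound 3 carry a methyl on that carbon, but each also differs from compound 2 and compound 4 elsewhere, so the part played by the hydroxy itself remains unresolved.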